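Series notes: change at the ring nitrogen toward compound 4

The source may report more compounds than this note shows. Statements on the series, on what has been measured and on what is new or still open speak of the compounds shown alone.

Within an assay on isolated protein for inhibition of thyroid hormone receptor beta (Homo sapiens), read by fluorescence, with a stated time of 30 min (on this read-out lower numbers stand for stronger inhibition and higher numbers for weaker inhibition), three compounds of the shared core have been measured. Compound 1 `COc1cc(C(=O)N2CCC(O)C(C)C2)cc2nc(NCc3cncc(Cl)c3)oc12` gives 7200 nM, and compound 2 `COc1cc(C(=O)N2CCC(O)C(C)C2)cc2nc(NCc3ccnc(Cl)c3)oc12` gives 6900 nM; the step of a 1.0-fold lower number from compound 1 to compound 2 (0.02 log units; within the scatter) does not separate them. Compound 3 `COc1cc(C(=O)N2CCC(O)C(C)C2)cc2nc(NCc3cc(Cl)ccc3F)oc12` gives 300 nM, the lowest number of the three; the steps of a 24-fold lower number from compound 1 to compound 3 (1.38 log units; beyond the scatter) and a 23-fold lower number from compound 2 to compound 3 (1.36 log units; beyond the scatter) are both large and beyond the scatter, so compound 3 stands alone at the low end of the numbers seen so far.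

Compound 4 `COc1cc(C(=O)N2CCC(O)C(C)C2)cc2nc(NC3(c4cccc(Cl)c4)CC3)oc12` carries 1-(3-chlorophenyl)cyclopropyl in place of 5-chloro-2-fluorobenzyl on a nitrogen on an aromatic ring. Among the compounds with values here, no measured step covers this kind of change: the two large steps to compound 3 each exchanged 5-chloropyridin-3-yl or 2-chloropyridin-4-yl for 5-chloro-2-fluorophenyl on the same saturated chain carbon, while compound 4 keeps a chlorine-bearing benzene ring, loses the fluorine and gains a three-membered ring at the carbon bound to the nitrogen. Nothing in the series shows how the loss of the fluorine or the added ring acts, so no direction can be assigned with confidence. The working expectation is a step of a 1.3-fold higher number from compound 3 to compound 4 (0.12 log units; within the scatter) of no size beyond the scatter, with a wide allowance either way. Compound 4 is therefore estimated at 400 nM in this assay, within a range from 100 nM to 2000 nM.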

Compound 4, half-maximal inhibitory concentration: 120 nM
For compound 4 the middle estimate is 3.3-fold (0.52 log units) above the measured one, and the stated range covers the measured number.
By their numbers in this assay, from the lowest: compound 4; then compound 3; then compounds 2 and 1 (each within the scatter of the next).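

In this assay, the place on a nitrogen on an aromatic ring takes more than a simple benzyl group: 1-(3-chlorophenyl)cyclopropyl in place of 5-chloro-2-fluorobenzyl gives a 2.5-fold lower number from compound 3 to compound 4 (0.40 log units; beyond the scatter), a modest step, although the entering group brings a three-membered non-aromatic ring and carries no fluorine. Against the groups holding a pyridine ring, the gaps grow beyond the large ones already seen for compound 3, with a 58-fold lower number from compound 2 to compound 4 (1.76 log units; beyond the scatter) and a 60-fold lower number from compound 1 to compound 4 (1.78 log units; beyond the scatter), so compound 4 now holds the low end of the four numbers, with its steps to all the others beyond the scatter. No outside measurement bears on this result, and the change stays a plain observation on these compounds.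

The compounds shown do not separate the loss of the fluorine from the entry of the three-membered ring, as both arrive in a single step. Still open, going by these compounds, is how the number would respond to 1-(5-chloro-2-fluorophenyl)cyclopropyl, which keeps the fluorine alongside the three-membered ring, or to a cyclobutane ring or two methyl groups in place of that ring.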